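The compounds below may be only part of what the source reports. "The series", "measured", "known", "first", "only" and "open" are said of these compounds alone.

Measured compounds in a functional assay on THP-1 cells (Homo sapiens) for cytotoxicity, read by MTT assay, with a stated time of 24 h; a higher number here means a weaker inhibitor, a lower number a stronger inhibitor:

Compound 1, `Cc1cc2ccccc2nc1-c1cn(CCC(F)(F)C(F)(F)C(F)(F)C(F)(F)C(F)(F)C(F)(F)C(F)(F)C(F)(F)F)nn1`: compound 1 gives > 100 ug/mL
Compound 2, `CCCc1cc2ccccc2nc1-c1cn(-c2ccc(F)cc2)nn1`: compound 2 gives > 100 ug/mL
Compound 3, `CCc1cc2ccccc2nc1-c1cn(CCC(F)(F)C(F)(F)C(F)(F)C(F)(F)C(F)(F)C(F)(F)C(F)(F)C(F)(F)F)nn1`: compound 3 gives > 100 ug/mL

Each of these three values is a limit of this assay rather than a number. The value of compound 1 is a limit. The value of compound 2 is a limit. The value of compound 3 is a limit. All three sit at the same point, (the limit of > 100 ug/mL in this assay, at which 3 of the 3 values shown sit), so none of them can be set in order against another.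

Compound 3 differs from compound 1 by methyl in place of hydrogen on a saturated chain carbon bound to an aromatic carbon, and the step that the two limits leave unreadable from compound 1 to compound 3 cannot be read because both values are limits. The difference between the cores of compound 1 and compound 2 is not broken down here.

Compound 4, `CCCCc1cc2ccccc2nc1-c1cn(-c2ccc(F)cc2)nn1`, has not yet been measured in this assay. It differs from compound 2 by methyl in place of hydrogen on a saturated chain carbon, three bonds along the chain from an aromatic carbon. This is the same kind of change as that from compound 1 to compound 3, but not the same: in the earlier pair the place is on a saturated chain carbon bound to an aromatic carbon, whereas here it is on a saturated chain carbon, three bonds along the chain from an aromatic carbon.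

For the measured compounds named here, since compound 2 gives only a limit, > 100 ug/mL, and the one comparable step left no readable size, the expectation for compound 4 is that it too will most likely return a limit, and the estimated step that the limit leaves unreadable from compound 2 to compound 4 is therefore taken as essentially flat. The estimate for compound 4 is 150 ug/mL, expected to lie between 60 ug/mL and 400 ug/mL.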

Compound 4, half-maximal inhibitory concentration: 78.3 ug/mL
Compound 4: middle estimate off by 1.9-fold (0.28 log units), on the high side, and the stated range covers the measured number.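

In this assay the change of methyl in place of hydrogen, on a saturated chain carbon, three bonds along the chain from an aromatic carbon, gives an at least 1.2-fold lower number from compound 2 to compound 4 (0.10 log units; that floor lies within the scatter). Compound 2 stands at a limit of the assay and compound 4 has a measured number, which makes this a floor on the propyl to butyl change on this one core, and a floor that does not pass the usual scatter. The step from compound 1 to compound 3, on the other core and at another place on the chain, cannot be read, which leaves no size to set beside the first one and shows neither that the change carries from one core to the other nor that it fails to: the limit of > 100 ug/mL in this assay, at which 3 of the 4 values shown sit.

Left open is whether a chain longer than butyl on the core of compound 4 would bring the number in this assay clearly beyond the scatter, and whether an amine or a carboxylic acid in place of the added methyl would read any differently. Also open, going by these compounds, is how a butyl group would read on the core of compound 1.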